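The source may hold more compounds than are shown below. What is called first, only, known or untested is meant among the compounds shown, and "the series" means these compounds.

Measured compounds in a functional assay on MCF7 cells (Homo sapiens) for cytotoxicity; a higher number here means a weaker inhibitor, a lower number a stronger inhibitor:
compound 1 `Nc1ccc(-c2nc3c(O)cccc3s2)cc1Cl`: 61400 nM
compound 2 `CC(=O)Nc1ccc(-c2nc3cc(O)ccc3s2)cc1C`: 72500 nM
compound 3 `Nc1ccc(-c2nc3ccccc3s2)cc1Cl`: < 1 nM (a limit)

Of the two actual numbers, compound 1 stands lowest, and compound 2 sits within the scatter of it, so no order between the two can be read. Compound 3 is reported only as a limit of this assay, not as a number (the limit of < 1 nM in this assay, at which 1 of the 3 values shown sits). Among the compounds with values here, the one measured step is an at least 61000-fold lower number from compound 1 to compound 3 (4.78 log units; beyond the scatter); it concerns hydroxy against hydrogen on the shared core and says nothing about the group changed below.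

Compound 4 `Cc1cc(-c2nc3c(O)cccc3s2)ccc1N` differs from compound 1 by methyl in place of chloro on an aromatic carbon. Within the data shown here, no measured step touches methyl against chloro. Compound 2 does carry a methyl, but it differs from compound 1 in more than one place, so its value only shows that a methyl-bearing member of the series also gives a weak number in this assay. Among the measured compounds shown here, with the hydroxy kept where it stands in compound 1, and no step bearing on the exchange, the expected change is none beyond the scatter: a 1.0-fold lower number from compound 1 to compound 4 (0.01 log units; within the scatter) is the estimate. Compound 4 is therefore expected to give about 60000 nM in this assay, with a likely range of 25000 nM to 150000 nM.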

Compound 4, half-maximal inhibitory concentration: > 100000 nM
Compound 4: a limit, no number; the forecaster's own chance of this, stated with the estimate: 10%; middle value at least 1.6-fold (0.22 log units) away from the limit.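

In this assay compound 4 gives > 100000 nM, which is a limit of the assay and not a number: the limit of > 100000 nM in this assay, at which 1 of the 4 values shown sits. Within the data shown here, the new step is an at least 1.6-fold higher number from compound 1 to compound 4 (0.21 log units; that floor lies within the scatter); this is the first measured reading of methyl in place of chloro on this aromatic carbon, ortho to an amino group, and the floor of the step lies within the scatter, so its true size stays hidden behind the limit. Among these compounds, what the step does show is that, with the hydroxy kept in place, this exchange does not lift the series out of the weak range, whereas the only large step so far, an at least 61000-fold lower number from compound 1 to compound 3 (4.78 log units; beyond the scatter), concerns the hydroxy and not this position.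

Whether methyl and chloro would still read alike without the hydroxy stays open: compound 3 is the only compound shown that lacks it, and it carries chloro. Among the compounds shown here, how a bromo, a methoxy or an ethyl group would read at this position also stays open, as does any position of the hydroxy other than the one shared by compound 1 and compound 4.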